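Phenyl for Cyano: Expected Cytotoxicity of Compound 4

The source may hold more compounds than are shown below. What is called first, only, known or untested is meant among the compounds shown, and "the series" means these compounds.

Measured so far:
compound 1, `CNC(=O)c1ccc(NCc2cncn2Cc2ccc(-c3ccccc3)cc2N)cc1-c1ccccc1`: > 1000 nM
compound 2, `Cc1cccc(-c2cccc(NCc3cncn3Cc3ccccc3)c2)c1C`: > 1000 nM
compound 3, `COC(=O)c1ccc(NCc2cncn2Cc2ccc(C#N)cc2)cc1-c1ccccc1`: > 10000 nM

In a toxicity assay on NIH3T3 cells (Mus musculus) for cytotoxicity, read by resazurin assay (a higher number here means that more compound is needed for the effect, a lower number that less compound is needed), compound 1 gives > 1000 nM, a limit of the assay rather than a number. Compound 2 also reaches only a limit, > 1000 nM. Compound 3 likewise sits at a limit, > 10000 nM, so no number is known for it. For the measured compounds named here, two values sit at the limit of > 1000 nM in this assay, at which 2 of the 3 values shown sit, and one at the limit of > 10000 nM in this assay, at which 1 of the 3 values shown sits; none of the three gives a measured concentration, and no step between measured compounds can be drawn.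

Compound 4 is `COC(=O)c1ccc(NCc2cncn2Cc2ccc(-c3ccccc3)cc2)cc1-c1ccccc1`. It differs from compound 3 by phenyl in place of cyano on an aromatic carbon, on an aromatic carbon of a six-membered aromatic ring of carbon only, para to a large group. Since compound 3 shows only a limit at > 10000 nM, the step from it cannot be measured against anything, and the expected step that the limit leaves unreadable from compound 3 to compound 4 is none beyond the usual scatter. Compound 4 is therefore estimated at 15000 nM, in a range from 3000 nM to 60000 nM, most likely reported again only as a limit.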

Compound 4, half-maximal effective concentration: > 1000 nM
Compound 4: a limit, no number (the forecaster's own chance of this, stated with the estimate: 80%); the middle value does not contradict the limit.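

Compound 3 and compound 4 are each known only as a limit, not a number, so no step can be read for phenyl in place of cyano. The compounds shown leave open at what concentration any of them takes effect, and whether this exchange changes it.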